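Rat oral exposure across the amide side-chain variants

The compounds below may be only part of what the source reports. "The series", "measured", "known", "first", "only" and "open" are said of these compounds alone.

Compound 1, `CC(C)c1ccc2c(Nc3cc(C(=O)N[C@@H](C)c4ccccc4)ccc3Sc3ccc(N)cc3)ncnc2n1`, gives 6490 ng.h/mL in an ADME assay on the whole organism (plasma, strain Sprague-Dawley) for pharmacokinetics, with Rattus norvegicus as the target, at a dose of 5 mg/kg by the oral route; a higher number here means more compound in the circulation at the dose given, a lower number less compound in the circulation.
Compound 2, `CC(C)c1ccc2c(Nc3cc(C(=O)N[C@@](C)(CO)c4ccccc4)ccc3Sc3ccc(N)cc3)ncnc2n1`, gives 900 ng.h/mL in this assay.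
Compound 3, `Cc1ccc([C@H](C)NC(=O)c2ccc(Sc3ccc(N)cc3)c(Nc3ncnc4nc(C(C)C)ccc34)c2)cc1`, gives 600 ng.h/mL in this assay.

Compound 3 stands at the low end of the three numbers: the step of a 1.5-fold lower number from compound 2 to compound 3 (0.18 log units; within the scatter) stays within the scatter, whereas the step of an 11-fold lower number from compound 1 to compound 3 (1.03 log units; beyond the scatter) lies beyond it. The remaining measured step, a 7.2-fold lower number from compound 1 to compound 2 (0.86 log units; beyond the scatter), concerns another place on the amide side chain and does not touch the aromatic ring changed here.

Compound 4, `CC(C)c1ccc2c(Nc3cc(C(=O)N[C@@H](C)c4ccc(Br)cc4)ccc3Sc3ccc(N)cc3)ncnc2n1`, differs from compound 3 by bromo in place of methyl on an aromatic carbon. Among the measured compounds shown here, no measured pair exchanges one substituent for another at this aromatic carbon; the only step at this position, an 11-fold lower number from compound 1 to compound 3 (1.03 log units; beyond the scatter), puts methyl where hydrogen stood, and compound 4 replaces that methyl rather than hydrogen. Nothing measured bears directly on the exchange, so the expectation for compound 4 in this assay is a step of no size beyond the scatter, no change at the digits printed from compound 3 to compound 4 (within the scatter). Compound 4 is estimated at 600 ng.h/mL, in a range from 200 ng.h/mL to 1800 ng.h/mL.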

Compound 4, area under the concentration-time curve: 3840 ng.h/mL
Compound 4: the middle estimate sits 6.4-fold (0.81 log units) below what was measured, outside the stated range (above it).
By their numbers in this assay, from the lowest: compounds 3 and 2 (each within the scatter of the next); then compounds 4 and 1 (each within the scatter of the next).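

In this assay the aromatic carbon para to a large group does not treat every substituent alike: a 6.4-fold higher number from compound 3 to compound 4 (0.81 log units; beyond the scatter) with bromo in place of methyl. Bromo in place of hydrogen gives a 1.7-fold lower number from compound 1 to compound 4 (0.23 log units; within the scatter) so the loss seen with methyl at this carbon does not extend to bromo. The 1-(4-bromophenyl)ethyl chain also stands clear of the 1-(hydroxymethyl)-1-phenylethyl chain, with a 4.3-fold higher number from compound 2 to compound 4 (0.63 log units; beyond the scatter) whereas the 1-(4-methylphenyl)ethyl chain stays within the scatter of that same chain.

Still open, from the compounds shown here alone, is whether an amine or a carboxylic acid at this carbon would stay with bromo or with methyl. Nothing at hand accounts for the difference between methyl and bromo at this position.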